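This account rests on a few compounds, and the source may have more. Where it says the series, first, only, none or still open, it means among the compounds named here.

Measured compounds:
- Compound 1 `CC/C=C/C(=O)Nc1cccc(Oc2nc(Nc3cccc(OC)c3)nc3c2CSCC3)c1`: 27200 nM
- Compound 2 `CCC/C=C/C(=O)Nc1cccc(Oc2nc(Nc3cccc(OC)c3)nc3c2CSCC3)c1`: 33800 nM
- Compound 3 `COc1cccc(Nc2nc3c(c(Oc4cccc(NC(=O)C=C(C)C)c4)n2)CSCC3)c1`: 19100 nM

All three numbers come from a functional assay on HeLa cells (Homo sapiens) for antiproliferative activity, read by MTT assay, with a stated time of 72 h; on this read-out lower numbers stand for stronger inhibition and higher numbers for weaker inhibition. Compound 3 gives 19100 nM, but this does not set it apart from the other two. One comparison is a 1.4-fold lower number from compound 1 to compound 3 (0.15 log units; within the scatter), and the other is a 1.8-fold lower number from compound 2 to compound 3 (0.25 log units; within the scatter).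

The next compound, compound 4 `C=C(F)C(=O)Nc1cccc(Oc2nc(Nc3cccc(OC)c3)nc3c2CSCC3)c1`, keeps the shared core and alters only the group on the carbonyl carbon: 1-fluoroethenyl in place of 2-methylprop-1-en-1-yl on a carbonyl carbon. In short, 1-fluoroethenyl takes the place of 2-methylprop-1-en-1-yl on a carbonyl carbon.

The measured steps that bear on this change are the ones above, together with a 1.2-fold higher number from compound 1 to compound 2 (0.09 log units; within the scatter), since all three alter this same group. None of them exceeds the scatter, so exchanging these chains has barely shifted the number in this assay. However, no measured compound carries fluorine, so these steps are only a loose guide, and the data favour no direction. No step beyond the scatter is therefore expected, though the uncertainty is wide.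

The expected change is a 1.3-fold lower number from compound 3 to compound 4 (0.10 log units; within the scatter). For compound 4, the estimated value is 15000 nM, within an expected range of 4000 nM to 40000 nM.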

Compound 4, half-maximal inhibitory concentration: 44800 nM
Compound 4: middle estimate off by 3.0-fold (0.48 log units), on the low side; the measured number lies above the stated range.
By their numbers in this assay, from the lowest: compounds 3, 1, 2 and 4 (each within the scatter of the next, the first and the last beyond it).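

In this assay, within the data shown here, the exchange of 2-methylprop-1-en-1-yl for 1-fluoroethenyl on the carbonyl carbon gives a 2.3-fold higher number from compound 3 to compound 4 (0.37 log units; beyond the scatter) and is the only step at this position that passes the usual scatter, so this group can shift the number, though modestly. The two other exchanges stay inside the scatter, with a 1.3-fold higher number from compound 2 to compound 4 (0.12 log units; within the scatter) and a 1.6-fold higher number from compound 1 to compound 4 (0.22 log units; within the scatter) as the printed steps, which means compound 4 separates clearly from compound 3 alone and cannot be ranked against the two straight-chain compounds. Nothing measured here accounts for why this one exchange reaches beyond the scatter.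

Compound 4 differs from compound 3 both in carrying fluorine and in having a smaller group, so a plain ethenyl group on the same carbonyl carbon would be needed to tell those two differences apart. What an amine-bearing chain, a carboxylic acid or a cyclopropyl ring would do at this position also remains open, as every group shown here is an open chain with one double bond.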